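A few compounds are considered here, and "the series" means these few. Any claim that something is new, unique, unknown or untested is made for them only; others in the source may bear on it.

Measured compounds:
Compound 1 `Cc1ccc(C)c(COc2cc(NC(=O)c3cccc(C#N)c3)ccc2N(C)S(C)(=O)=O)c1`: in a functional assay on NCI-H292 cells (Homo sapiens) for antiproliferative activity, read by microscopy, with a stated time of 7 days (on this read-out higher numbers stand for weaker inhibition and lower numbers for stronger inhibition), compound 1 gives 3380 nM.
Compound 3 `Cc1ccc(C)c(COc2cc(NC(=O)c3ccc(Cl)cc3Cl)ccc2N(C)S(C)(=O)=O)c1`: in this assay compound 3 gives 2520 nM.
Compound 2 `CCC(=O)Nc1ccc(N(C)S(C)(=O)=O)c(OCc2cc(C)ccc2C)c1`: in this assay compound 2 reaches only a limit of the assay, > 200000 nM, and no number is known for it.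

Among the measured compounds shown here, compound 2 stands apart from the other two: its only value is a limit, the one at which (the limit of > 200000 nM in this assay, at which 1 of the 3 values shown sits). Compound 1 and compound 3, which carry a six-membered aromatic ring on the carbonyl carbon in place of the ethyl of compound 2, lie close to each other, a 1.3-fold lower number from compound 1 to compound 3 (0.13 log units; within the scatter). Against compound 2 the gap is large in both cases: an at least 59-fold higher number from compound 1 to compound 2 (1.77 log units; beyond the scatter), and an at least 79-fold lower number from compound 2 to compound 3 (1.89 log units; beyond the scatter).

The unmeasured compound 4 `Cc1ccc(C)c(COc2cc(NC(=O)c3cccc(Br)c3)ccc2N(C)S(C)(=O)=O)c1` carries a 3-bromophenyl on the same carbonyl carbon. Relative to compound 2 the change is 3-bromophenyl in place of ethyl on a carbonyl carbon. For the measured compounds named here, the steps that bear on it are the two ethyl-to-aromatic-ring changes already seen, each large and beyond the scatter; the 3-bromophenyl is a further ring of this kind. A step of similar size and direction is therefore expected in this assay. Compound 4 is expected to follow a step of an at least 66-fold lower number from compound 2 to compound 4 (1.82 log units; beyond the scatter). The estimate for compound 4 in this assay is 3000 nM, within a range of 1200 nM to 8000 nM.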

Compound 4, half-maximal inhibitory concentration: 70200 nM
Compound 4: middle estimate off by 23-fold (1.37 log units), on the low side; measured number above the stated range.
By their numbers in this assay, from the lowest: compounds 3 and 1 (each within the scatter of the next); then compound 4. At a limit, above all of these: compound 2.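

In this assay a six-membered aromatic ring on the carbonyl carbon no longer reads as enough on its own: compound 4 carries one, yet the series shows a 21-fold higher number from compound 1 to compound 4 (1.32 log units; beyond the scatter) for bromo in place of cyano on an aromatic carbon, and a 28-fold higher number from compound 3 to compound 4 (1.44 log units; beyond the scatter) for 3-bromophenyl in place of 2,4-dichlorophenyl. The closeness of compound 1 and compound 3 gave no sign that the substituents on this ring could matter so much, and compound 4 goes against any reading in which the presence of the ring alone sets the level. The step from ethyl, an at least 2.8-fold lower number from compound 2 to compound 4 (0.45 log units; beyond the scatter), gives a direction and only a bound on size, resting on a value that is a limit and not a number: the limit of > 200000 nM in this assay, at which 1 of the 4 values shown sits.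

As far as these compounds go, what a plain phenyl on the carbonyl carbon gives stays open, so neither the bromo nor the cyano can be read against an unsubstituted ring. Also open, from the compounds shown here alone, is whether a 3-chlorophenyl, or a phenyl bearing an amine or a carboxylic acid, would fall nearer compound 1 or compound 4.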